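Moving the hydroxyl on the piperidine of compound 2

This account rests on a few compounds, and the source may have more. Where it says the series, first, only, none or still open, it means among the compounds named here.

Compound 1 `Cc1ccc(S(=O)(=O)c2nc3ccccc3nc2N2CCCC2)cc1` reaches only a limit in a functional assay on PC-3 cells (Homo sapiens) for cytotoxicity, read by MTT assay, with a stated time of 72 h (on this read-out lower numbers stand for stronger inhibition and higher numbers for weaker inhibition), namely > 50000 nM. Compound 2 `Cc1ccc(S(=O)(=O)c2nc3ccccc3nc2N2CCCC(O)C2)cc1` gives 5330 nM, and compound 3 `COc1ccc(S(=O)(=O)c2nc3ccccc3nc2N2CCCC(O)C2)cc1` gives 3410 nM. These two numbers sit within the scatter of each other, and the remaining value is a limit (the limit of > 50000 nM in this assay, at which 1 of the 3 values shown sits). Of the measured steps, an at least 9.3-fold lower number from compound 1 to compound 2 (0.97 log units; beyond the scatter) is the only one beyond the scatter, whereas a 1.6-fold lower number from compound 2 to compound 3 (0.19 log units; within the scatter) stays within it. Compound 4 `Cc1ccc(S(=O)(=O)c2nc3ccccc3nc2N2CCC(O)CC2)cc1` differs from compound 2 by 4-hydroxypiperidin-1-yl in place of 3-hydroxypiperidin-1-yl on an aromatic carbon. For the measured compounds named here, no measured step moves the hydroxyl within the same ring, so no shift beyond the scatter is expected. The expected step is a 1.1-fold lower number from compound 2 to compound 4 (0.03 log units; within the scatter). For compound 4 the estimate is 5000 nM, with a range from 2000 nM to 15000 nM.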

Compound 4, half-maximal inhibitory concentration: 9520 nM
The estimate for compound 4 lay 1.9-fold (0.28 log units) below the measured number; measured number inside the range.
By their numbers in this assay, from the lowest: compounds 3, 2 and 4 (each within the scatter of the next, the first and the last beyond it). At a limit, above all of these: compound 1.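

In this assay, moving the hydroxyl within the ring gives a 1.8-fold higher number from compound 2 to compound 4 (0.25 log units; within the scatter), so at this position the two hydroxypiperidines are not separated. 4-Hydroxypiperidin-1-yl in place of pyrrolidin-1-yl gives an at least 5.2-fold lower number from compound 1 to compound 4 (0.72 log units; beyond the scatter), so the lower number seen with 3-hydroxypiperidin-1-yl is not confined to that one placement of the hydroxyl. This step starts from a limit rather than a number: the limit of > 50000 nM in this assay, at which 1 of the 4 values shown sits.

Whether the hydroxyl or the larger ring accounts for the lower numbers remains open. Plain piperidin-1-yl and 4-methoxypiperidin-1-yl at this position would separate the two.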